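This account rests on a few compounds, and the source may have more. Where it says the series, first, only, none or still open, it means among the compounds named here.

Measured in a functional assay (Saphenous vein) for binding affinity, with Oryctolagus cuniculus as the target; on this read-out lower numbers stand for tighter binding and higher numbers for weaker binding:
compound 1 `CN(C)[C@H]1C[C@H](c2c[nH]c3ccc(C(=O)NCc4ccccc4)cc32)C1` gives 1260 nM
compound 2 `Cc1nc(Cc2ccc3[nH]cc([C@H]4C[C@H](N(C)C)C4)c3c2)n[nH]1` gives 6610 nM
compound 3 `CN(C)[C@H]1C[C@H](c2c[nH]c3ccc(CN4C(=O)NC(C)(C)C4=O)cc32)C1` gives 589 nM

Compound 2 has the highest number of the three, and its gaps to compound 1 and compound 3 both lie beyond the scatter. Compound 4 `CN(C)[C@H]1C[C@H](c2c[nH]c3ccc(CN4C(=O)CNC4=O)cc32)C1` is not yet measured. It differs from compound 2 by 2,5-dioxoimidazolidin-1-yl in place of 5-methyl-1H-1,2,4-triazol-3-yl on a saturated chain carbon bound to an aromatic carbon with 2,5-dioxoimidazolidin-1-yl in place of 5-methyl-1H-1,2,4-triazol-3-yl on a saturated chain carbon bound to an aromatic carbon. For the measured compounds named here, no measured pair isolates this change. Compound 4 most resembles compound 3, whose 589 nM anchors the expectation. The expected step is an 8.3-fold lower number from compound 2 to compound 4 (0.92 log units; beyond the scatter) toward a lower number in this assay and beyond the scatter. For compound 4 the estimate is 800 nM with an expected range from 300 nM to 2200 nM for the measurement.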

Compound 4, dissociation constant: 9330 nM
Compound 4: the middle estimate sits 12-fold (1.07 log units) below what was measured; the measured number lies above the stated range.
By their numbers in this assay, from the lowest: compound 3; then compound 1; then compounds 2 and 4 (each within the scatter of the next).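

Setting 2,5-dioxoimidazolidin-1-yl in place of 5-methyl-1H-1,2,4-triazol-3-yl on a saturated chain carbon bound to an aromatic carbon gives a 1.4-fold higher number from compound 2 to compound 4 (0.15 log units; within the scatter) in this assay, so an aromatic and a non-aromatic ring are not separated at this position. The 2,5-dioxoimidazolidin-1-yl ring alone does not carry the number of compound 3 at 589 nM, whose ring bears methyl groups, since compound 4 gives 9330 nM. No measurement available here accounts for this result.

The compounds shown leave open whether a single methyl group on the 2,5-dioxoimidazolidin-1-yl ring would suffice, and how an open-chain urea would read on this carbon.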